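The source may hold more compounds than are shown below. What is called first, only, known or untested is meant among the compounds shown, and "the series" means these compounds.

Measured in a functional assay on K562 cells (Homo sapiens) for antiproliferative activity, read by MTT assay, with a stated time of 48 h; on this read-out higher numbers stand for weaker inhibition and lower numbers for stronger inhibition:
- compound 1 `Oc1ccc2cc1Oc1ccc(cc1)CCc1ccc(CN3CCN(Cc4ccccc4)CC3)c(O)c1-c1ccc(cc1O)CC2`: > 20000 nM (a limit)
- compound 2 `CN1CCN(Cc2ccc3c(c2O)-c2ccc(cc2O)CCc2ccc(O)c(c2)Oc2ccc(cc2)CC3)CC1`: 3310 nM

Among the measured compounds shown here, compound 2, at 3310 nM, holds the only actual number so far. Compound 3 `CC(C)(C)OC(=O)N1CCN(Cc2ccc3c(c2O)-c2ccc(cc2O)CCc2ccc(O)c(c2)Oc2ccc(cc2)CC3)CC1` is not yet measured and carries tert-butoxycarbonyl in place of methyl on an amine nitrogen in a ring. For the measured compounds named here, the one measured step bearing on this is an at least 6.0-fold lower number from compound 1 to compound 2 (0.78 log units; beyond the scatter), where hydrogen replaces phenyl on a saturated chain carbon bound to an amine nitrogen in a ring. Its size is known only as a bound. By analogy, a moderate move toward weaker inhibition in this assay is expected, namely a 2.1-fold higher number from compound 2 to compound 3 (0.33 log units; beyond the scatter). For compound 3 the estimated value is 7000 nM, with an expected range of 2500 nM to 20000 nM.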

Compound 3, half-maximal inhibitory concentration: > 20000 nM
Compound 3: no number, only a limit; the forecaster's own chance of this, stated with the estimate: 25%; at least 2.8-fold (0.45 log units) between middle value and limit.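

In this assay, putting tert-butoxycarbonyl in place of methyl on the amine nitrogen in the ring gives an at least 6.0-fold higher number from compound 2 to compound 3 (0.78 log units; beyond the scatter), so the loss at this nitrogen is not confined to the benzyl group of compound 1. Of the three groups shown there, only the methyl of compound 2 gives an actual number. Compound 3, like compound 1, gives only a limit, so the step between them cannot be read: the limit of > 20000 nM in this assay, at which 2 of the 3 values shown sit.

Going by these compounds, whether a hydrogen, an ethyl or an acetyl group on this nitrogen would match compound 2 remains open.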